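Hydroxy for chloro on the aryl of the series

A few compounds are considered here, and "the series" means these few. Any claim that something is new, unique, unknown or untested is made for them only; others in the source may bear on it.

Three compounds sharing one core have been run in a functional assay on the whole organism (strain albino) for inhibition, with Rattus norvegicus as the target, read by paw edema, with stated times of 1 h and 2 h, at a dose of 100 mg/kg by the oral route; on this read-out lower numbers stand for less inhibition and higher numbers for more inhibition at the one dose given (going by the name of the read-out). Compound 1 `N#Cc1c(-c2ccc(O)cc2)nc(SCC(=O)Nn2c(COc3ccc(Cl)cc3Cl)nc3ccccc3c2=O)[nH]c1=O` gives 68.4%, compound 2 `Cn1c(SCC(=O)Nn2c(COc3ccc(Cl)cc3Cl)nc3ccccc3c2=O)nc(-c2ccccc2)c(C#N)c1=O` gives 59.7%, and compound 3 `Cn1c(SCC(=O)Nn2c(COc3ccc(Cl)cc3Cl)nc3ccccc3c2=O)nc(-c2ccc(Cl)cc2)c(C#N)c1=O` gives 73.7%. Going by the values given here, compound 3 stands at the top of the three numbers; compound 1 lies within the scatter of it, while compound 2 lies beyond it, the single measured step being a number 14 percentage points higher from compound 2 to compound 3 (beyond the scatter).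

Compound 4 `Cn1c(SCC(=O)Nn2c(COc3ccc(Cl)cc3Cl)nc3ccccc3c2=O)nc(-c2ccc(O)cc2)c(C#N)c1=O` is the next member and is to be measured in this assay. It differs from compound 3 by hydroxy in place of chloro on an aromatic carbon. Among the compounds with values here, no measured pair isolates exactly this exchange. Within the data shown here, the only single-point step on the same aromatic carbon is the one from compound 2 to compound 3, which added chloro in place of hydrogen and raised the number by a modest amount. Compound 1 carries the same hydroxyphenyl as compound 4 but also lacks the methyl of the core, so its value is only an indication; compound 1 and compound 3 sit within the scatter of each other.

The step from compound 3 to compound 4 is therefore expected to be small, as a number 7.7 percentage points lower from compound 3 to compound 4 (within the scatter), likely within the scatter and if anything downward. Compound 4 is expected to give 66%, in a range from 56% to 76%.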

Compound 4, a percentage reported as inhibition, in the whole organism at one dose (the size of the read-out at that dose, not a potency): 86%
For compound 4 the middle estimate is 20 percentage points below the measured one, and the stated range ends below it.
By their numbers in this assay, from the lowest: compounds 2, 1 and 3 (each within the scatter of the next, the first and the last beyond it); then compound 4.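

In this assay, 4-chlorophenyl to 4-hydroxyphenyl is not a neutral exchange on this aromatic carbon: it gives a number 12.3 percentage points higher from compound 3 to compound 4 (beyond the scatter), so the two groups can now be told apart at this place. Measured against hydrogen on the same carbon, chloro gives a number 14 percentage points higher from compound 2 to compound 3 (beyond the scatter) and hydroxy gives a number 26.3 percentage points higher from compound 2 to compound 4 (beyond the scatter), so both groups go with a higher number on this core, and hydroxy reaches the top of the four compounds, with each of its steps from the other three beyond the scatter. Going by these compounds alone, the core methyl also counts when the 4-hydroxyphenyl is held fixed, as methyl in place of hydrogen on the aromatic nitrogen gives a number 17.6 percentage points higher from compound 1 to compound 4 (beyond the scatter), which is the first single-point reading at that nitrogen and makes compound 1 a poor stand-in for the effect of the aryl group.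

No supporting data in hand account for either gain. Open, going by these compounds, are whether the rise extends to a methoxy or an amine on the same aromatic carbon, whether the methyl step holds with 4-chlorophenyl in place of 4-hydroxyphenyl, and how these numbers at one dose would compare across a range of doses.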